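The source may report more compounds than this note shows. Statements on the series, on what has been measured and on what is new or still open speak of the compounds shown alone.

Compound 1 `COc1cc(NC(C)CCCNC(=O)NNC(=O)Nc2ccc(Cl)c(C(F)(F)F)c2)c2ncccc2c1` has been tested in a functional assay on MCF7 cells (Homo sapiens) for inhibition, read by MTT assay, with a stated time of 4 days (a lower number here means a stronger inhibitor, a higher number a weaker inhibitor), and compound 1 gives 2000 nM as its half-maximal inhibitory concentration. Within the data shown here, the only other measured compound is compound 2 `COc1cc(NC(C)CCCNC(=O)NNC(=O)NCCNC(c2ccccc2)(c2ccccc2)c2ccccc2)c2ncccc2c1` and compound 2 gives 2000 nM in the same test. Compound 1 therefore stands level with compound 2, and neither can be ranked over the other.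

Compound 3 `COc1cc(NC(C)CCCNC(=O)NNC(=O)NCCCO)c2ncccc2c1` has not yet been measured. It keeps the core of compound 1 and changes one end group, as counted in 3-hydroxypropyl in place of 4-chloro-3-(trifluoromethyl)phenyl on an amide-type nitrogen for this swap: 3-hydroxypropyl in place of 4-chloro-3-(trifluoromethyl)phenyl on an amide-type nitrogen. The swap is a large one, since an aromatic ring leaves and no ring enters. Among the measured compounds shown here, no measured step between closely related compounds shows what such a change does in this assay for this series. With no evidence for a direction, no step beyond the scatter is expected. The expected change is a 1.5-fold higher number from compound 1 to compound 3 (0.18 log units; within the scatter) by this estimate, with wide uncertainty on either side. For compound 3 the estimated value is 3000 nM with 500 nM to 20000 nM as its expected range.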

Compound 3, half-maximal inhibitory concentration: 13000 nM
Beside the measured number, compound 3's estimate is 4.3-fold (0.64 log units) below it; the measured number falls inside the stated range.
By their numbers in this assay, from the lowest: compounds 1 and 2 (each within the scatter of the next); then compound 3.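

This result shows that the group on the amide-type nitrogen whose other neighbour is the carbonyl carbon can shift the reading in this assay: putting 3-hydroxypropyl in place of 4-chloro-3-(trifluoromethyl)phenyl gives a 6.5-fold higher number from compound 1 to compound 3 (0.81 log units; beyond the scatter). So this end of the molecule is not free to change without consequence, and of the two groups compared here, the substituted aromatic ring goes with the stronger inhibition, while the hydroxyl-bearing chain goes with the weaker. The swap changes several things at once, removing a ring, chlorine and fluorine and adding an oxygen, and nothing measured here explains the loss or singles out which of these changes matters.

The compounds shown leave open whether the aromatic ring itself or the chlorine and trifluoromethyl on it carry the difference, a question that a plain phenyl group would help to answer. They also leave open whether the hydroxyl or the chain is what counts, which a plain propyl group, a longer chain ending in a hydroxyl or a chain ending in an amine could begin to separate.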